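This account rests on a few compounds, and the source may have more. Where it says the series, first, only, none or still open, it means among the compounds named here.

Measured compounds:
- Compound 1 `Nc1nc(Cl)c2ncn(Cc3ccc(CCl)cc3)c2n1` — in a functional assay on SK-MEL-2 cells (Homo sapiens) for cytotoxicity, read by sulforhodamine B assay, with a stated time of 48 h (on this read-out higher numbers stand for weaker inhibition of growth and lower numbers for stronger inhibition of growth), compound 1 gives 11500 nM
- Compound 2 `ClCc1ccc(Cn2cnc3nc(Cl)nc(Cl)c32)cc1` — in this assay compound 2 gives 1120 nM
- Compound 3 `ClCc1ccccc1Cn1cnc2ncnc(Cl)c21` — in this assay compound 3 gives 4160 nM

Among these three numbers compound 3 holds the second highest. Its nearest neighbour is compound 1, whose number is higher by a gap beyond the usual scatter; the furthest is compound 2, whose number is lower, also by a gap beyond the scatter. So compound 3 sits between the two, closer to the weaker of them.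

The step to compound 4 `ClCc1ccccc1Cn1cnc2nc(Cl)nc(Cl)c21` consists of one change: chloro in place of hydrogen on an aromatic carbon. Among the compounds with values here, no step between two measured compounds reproduces exactly this change, so there is no directly comparable measured pair. What the data do show is that compound 2, which carries chloro at that same carbon, gives a lower number in this assay than compound 1, which carries amino there; this is only a comparison of two values, not a measured step of the kind made here.

On that basis the step from compound 3 to compound 4 is expected to be a moderate decrease in the number, beyond the scatter, as a 2.8-fold lower number from compound 3 to compound 4 (0.44 log units; beyond the scatter). Compound 4 is therefore estimated to give 1500 nM, with a range from 500 nM to 5000 nM.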

Compound 4, concentration for 50% growth inhibition: 2750 nM
For compound 4 the middle estimate is 1.8-fold (0.26 log units) below the measured one; the measured number falls inside the stated range.
By their numbers in this assay, from the lowest: compound 2; then compounds 4 and 3 (each within the scatter of the next); then compound 1.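

With this pair the change can be read directly: chloro in place of hydrogen on the aromatic carbon between two ring nitrogen atoms gives a 1.5-fold lower number from compound 3 to compound 4 (0.18 log units; within the scatter) in this assay. On this read-out, hydrogen and chloro at this carbon are therefore not told apart, so the lower number of compound 2 against compound 1, which carry chloro and amino there, says nothing of a gain from chloro over hydrogen. Nothing measured here speaks to the reason for this result.

As far as these compounds go, whether the same change gives so small a step with the chloromethyl group placed as in compound 2 stays open. Also open, from the compounds shown here alone, is how a methoxy group, a dimethylamino group or a carboxylic acid at this carbon would compare with hydrogen and chloro in this assay.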